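The source may hold more compounds than are shown below. What is called first, only, known or untested is meant among the compounds shown, and "the series" means these compounds.

Measured compounds in an ADME assay for permeability, using PAMPA, with a stated time of 3 h; on this read-out lower numbers stand for lower permeability and higher numbers for higher permeability:
- compound 1, `O=C(Nc1cccc([N+](=O)[O-])c1)c1cc(Cl)ccc1O`, gives 19.5 10^-6 cm/s
- compound 2, `O=C(Nc1ccc([N+](=O)[O-])c(Cl)c1)c1cc(Cl)ccc1O`, gives 12.3 10^-6 cm/s
- compound 3, `O=C(Nc1cccc(F)c1)c1cc(Cl)ccc1O`, gives 3.7 10^-6 cm/s

Compound 3 stands lowest of the three numbers in this assay; its nearest neighbour is compound 2, whose number is higher by a gap beyond the scatter, and compound 1 lies furthest above it. Going by the values given here, the one single-point step measured so far is a 5.3-fold lower number from compound 1 to compound 3 (0.72 log units; beyond the scatter).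

Compound 4, `CC(C)(C)c1cccc(NC(=O)c2cc(Cl)ccc2O)c1`, is not yet measured. Against compound 3 the change is:
tert-butyl in place of fluoro on an aromatic carbon

Among the compounds with values here, no measured step covers tert-butyl, so none of the steps bears directly on this change. Within the data shown here, the only step measured concerns fluoro in place of nitro, and it moved the number down from compound 1 to compound 3; what compound 4 does with tert-butyl cannot be read from it. The direction for compound 4 in this assay is therefore open, and the expected step of a 1.9-fold higher number from compound 3 to compound 4 (0.28 log units; within the scatter) is held to a modest rise with a wide range. Compound 4 is estimated at 7 10^-6 cm/s, between 2.5 10^-6 cm/s and 20 10^-6 cm/s.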

Compound 4, apparent permeability: 18.7 10^-6 cm/s
Compound 4: the middle estimate sits 2.7-fold (0.43 log units) below what was measured; the measured number falls inside the stated range.
By their numbers in this assay, from the lowest: compound 3; then compounds 2, 4 and 1 (each within the scatter of the next).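

In this assay, tert-butyl in place of fluoro on an aromatic carbon gives a 5.1-fold higher number from compound 3 to compound 4 (0.70 log units; beyond the scatter). Tert-butyl in place of nitro at the same position gives a 1.0-fold lower number from compound 1 to compound 4 (0.02 log units; within the scatter), so nitro and tert-butyl cannot be told apart here, while fluoro alone stands apart among these three groups at this position. No measurement at hand accounts for this result.

On these data alone, whether an amine, a carboxylic acid or a methyl group at this position would fall with fluoro or with nitro and tert-butyl remains open. Also open, as far as these compounds go, is whether these steps would carry over to a core with another group in place of its chloro.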